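The source may hold more compounds than are shown below. What is called first, only, known or untested is meant among the compounds shown, and "the series" means these compounds.

In a physicochemical assay for solubility, read by HPLC, using the shake flask method, measured as kinetic solubility, with a stated time of 20 h, at pH 6.5, tested at 200 uM (on this read-out higher numbers stand for higher solubility and lower numbers for lower solubility), compound 2 `NS(=O)(=O)c1cccc(-c2ccc3nccc(-c4ccncc4)c3n2)c1` gives < 5000 nM, which is a limit and not a number. Compound 1 `O=S(=O)(CCO)c1cccc(-c2ccc3nccc(-c4ccncc4)c3n2)c1` gives 55000 nM in this assay. Compound 3 `CS(=O)(=O)c1cccc(-c2ccc3nccc(-c4ccncc4)c3n2)c1` has methyl in place of amino on a sulfonyl sulfur. Within the data shown here, the only measured step at this sulfur is large: an at least 11-fold lower number from compound 1 to compound 2 (1.04 log units; beyond the scatter). Amino leaves again in compound 3, so a moderate rise in this assay is expected, smaller than the step of an at least 11-fold lower number from compound 1 to compound 2 (1.04 log units; beyond the scatter). The expected step is an at least 2.4-fold higher number from compound 2 to compound 3 (0.38 log units; beyond the scatter). The estimate for compound 3 is 12000 nM, with an expected range of 4000 nM to 40000 nM.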

Compound 3, solubility: < 5000 nM
Compound 3 gave a limit, no number; the forecaster's own chance of this, stated with the estimate: 25%; middle value at least 2.4-fold (0.38 log units) from the limit.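

In this assay hydrogen in place of hydroxymethyl on a saturated chain carbon bound to a sulfonyl sulfur gives an at least 11-fold lower number from compound 1 to compound 3 (1.04 log units; beyond the scatter) and so the large fall is not confined to amino. Compound 3 stands at a limit, not a number, as does compound 2, so the step between them cannot be read. Only compound 1 stands clear of that shared limit: the limit of < 5000 nM in this assay, at which 2 of the 3 values shown sit.

On these data alone, how far compound 2 and compound 3 lie under the limit stays open. Also open, as far as these compounds go, is whether a longer chain, a carboxylic acid or an amine on the sulfonyl sulfur would match compound 1.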